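Lengthening the chain by one carbon on a urea

The source may hold more compounds than are shown below. What is called first, only, known or untested is meant among the compounds shown, and "the series" means these compounds.

Measured so far in an assay on isolated protein for inhibition of acyl-CoA:cholesterol acyltransferase (Oryctolagus cuniculus); on this read-out higher numbers stand for weaker inhibition and lower numbers for stronger inhibition:
Compound 1 `CCc1ccc(NC(=O)Nc2c(C(C)C)cccc2C(C)C)cc1` gives 100 nM.
Compound 2 `CC(C)c1cccc(C(C)C)c1NC(=O)Nc1ccccc1` gives 910 nM.
Compound 3 `CCCCCCCCCCc1ccc(NC(=O)Nc2c(C(C)C)cccc2C(C)C)cc1` gives 13 nM.

Compound 3 stands lowest of the three numbers, and thus as the strongest inhibitor here; both of its steps to the others lie beyond the scatter. The three compounds share one core and differ only in the group on the outer aromatic ring: hydrogen in compound 2, ethyl in compound 1, decyl in compound 3.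

Compound 4 `CCCCCCCCCCCc1ccc(NC(=O)Nc2c(C(C)C)cccc2C(C)C)cc1` carries the change (methyl in place of hydrogen on a saturated chain carbon, ten or more bonds along the chain from an aromatic carbon).

For the measured compounds named here, two measured steps bear on this. Removing ethyl gave a 9.1-fold higher number from compound 1 to compound 2 (0.96 log units; beyond the scatter), and adding decyl in its place gave a 70-fold lower number from compound 2 to compound 3 (1.85 log units; beyond the scatter); the part of that gain beyond ethyl was a 7.7-fold lower number from compound 1 to compound 3 (0.89 log units; beyond the scatter). So each lengthening of the chain has lowered the number, but the gain per added carbon has shrunk as the chain grew. Adding one more carbon at the far end of a chain that is already decyl is therefore expected to give only a small step, if any, in this assay: compound 4 is estimated at a 1.3-fold lower number from compound 3 to compound 4 (0.11 log units; within the scatter), which likely falls within the scatter. The expected value for compound 4 is 10 nM, with a range from 4 nM to 30 nM.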

Compound 4, half-maximal inhibitory concentration: 9 nM
Estimate against measurement, compound 4: 1.1-fold (0.05 log units) above, and the stated range covers the measured number.
By their numbers in this assay, from the lowest: compounds 4 and 3 (each within the scatter of the next); then compound 1; then compound 2.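

In this assay, for the compounds shown here, methyl in place of hydrogen at the far end of the decyl chain gives a 1.4-fold lower number from compound 3 to compound 4 (0.16 log units; within the scatter), so at this position the extra carbon produces no step that can be told apart from repeated measurement, and compound 3 and compound 4 read as equal. The large steps belong to the long chain as a whole: undecyl in place of hydrogen on an aromatic carbon gives a 100-fold lower number from compound 2 to compound 4 (2.00 log units; beyond the scatter), and lengthening the ethyl group to undecyl gives an 11-fold lower number from compound 1 to compound 4 (1.05 log units; beyond the scatter), yet these add nothing that can be separated from what the decyl chain of compound 3 already gave. No measured information at hand explains why this last carbon leaves the number unchanged.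

The compounds shown leave open what a longer chain, such as dodecyl or hexadecyl, would do, and whether the number would stay level or start to rise. They also leave open how the number moves across the gap between ethyl and decyl, with butyl or hexyl, and whether the chain end would tolerate a carboxylic acid or an amine.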